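Branching a pentyloxy chain on a shared cyclohexyl imidazolone core

The compounds below may be only part of what the source reports. "The series", "measured", "known", "first", "only" and "open" are said of these compounds alone.

Three compounds share one core and differ only in the group on the phenyl ring. Compound 1 `CCCCc1ccc(-c2c(C)[nH]c(=O)n2C2CCCCC2)cc1` carries a butyl group and in a functional assay on brain (Rattus norvegicus, strain Wistar) for inhibition (on this read-out higher numbers stand for weaker inhibition and lower numbers for stronger inhibition), compound 1 gives 27100 nM. Compound 2 `Cc1[nH]c(=O)n(C2CCCCC2)c1-c1ccc(CC(C)C)cc1` carries an isobutyl group, and in this assay compound 2 gives 10900 nM. Compound 3 `CCCCCOc1ccc(-c2c(C)[nH]c(=O)n2C2CCCCC2)cc1` carries a pentyloxy group, and in this assay compound 3 gives 9100 nM. The step of a 2.5-fold lower number from compound 1 to compound 2 (0.40 log units; beyond the scatter) is modest, the step of a 3.0-fold lower number from compound 1 to compound 3 (0.47 log units; beyond the scatter) likewise, while the step of a 1.2-fold lower number from compound 2 to compound 3 (0.08 log units; within the scatter) is within the scatter, so compounds 2 and 3 cannot be ordered.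

Compound 4 `Cc1[nH]c(=O)n(C2CCCCC2)c1-c1ccc(OCCC(C)C)cc1` has not yet been measured. It differs from compound 3 by isopropyl in place of propyl on a saturated chain carbon, two bonds along the chain from an oxygen on an aromatic ring. The same kind of change, (isopropyl in place of propyl on a saturated chain carbon bound to an aromatic carbon), links compound 1 to compound 2, but there the place is on a saturated chain carbon bound to an aromatic carbon, whereas here it is two bonds along the chain from an oxygen on an aromatic ring. The cores of compounds 1 and 3 differ by pentyloxy in place of butyl on an aromatic carbon.

Because compound 2 stands at 10900 nM after the earlier branching, compound 4 is expected to show a step of a 1.9-fold lower number from compound 3 to compound 4 (0.28 log units; within the scatter), somewhat smaller than that earlier one given the different place. Compound 4 is thus estimated at 4800 nM, between 1900 nM and 12000 nM.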

Compound 4, half-maximal inhibitory concentration: 7200 nM
Estimate against measurement, compound 4: 1.5-fold (0.18 log units) below, and the stated range covers the measured number.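

In this assay, among these compounds, compound 4 shows a 1.3-fold lower number from compound 3 to compound 4 (0.10 log units; within the scatter), so compound 3 and compound 4 cannot be ordered, and a 1.5-fold lower number from compound 2 to compound 4 (0.18 log units; within the scatter) leaves compound 2 and compound 4 unordered as well, while a 3.8-fold lower number from compound 1 to compound 4 (0.58 log units; beyond the scatter) is the only one of these new steps beyond the scatter. Read on the two cores, the branching change gives steps that cannot be told apart: the same change on two cores in this assay, a 2.5-fold lower number (0.40 log units; beyond the scatter) from compound 1 to compound 2 and a 1.3-fold lower number (0.10 log units; within the scatter) from compound 3 to compound 4, 2.0-fold (0.29 log units) apart, within the scatter of two such steps. Among the compounds shown here, this shows no measurable difference in how the change behaves on the two cores, but it does not show that the change carries over unaltered: only the step on the core of compound 1 lies beyond the scatter, and each core offers just one pair.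

The compounds shown leave open whether the same branching would matter on a longer chain, or on a chain ending in an amine or a carboxylic acid. They also leave open whether a smaller ring in place of the cyclohexyl group would shift the numbers more than these chain changes do.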